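The compounds below may be only part of what the source reports. "The series", "measured", "known", "first", "only" and "open" are said of these compounds alone.

Measured in a functional assay on SW480 cells (Homo sapiens) for antiproliferative activity, read by MTT assay, with a stated time of 48 h; a higher number here means a weaker inhibitor, a lower number a stronger inhibitor:
- Compound 1 `CCCCCC(CCO)n1cnc2c(NC)ncnc21`: > 50000 nM, a limit of the assay
- Compound 2 `CCCCCCCCCC(CCO)n1cnc2c(OC)ncnc21`: 3250 nM

For the measured compounds named here, compound 2 holds the only actual number so far, as the other result is a limit. Going by the values given here, compound 1 and compound 2 differ in more than one place, so the series offers no measured step between compounds that differ in one place.

Compound 3 `CCCCCCCCCC(CCO)n1cnc2c(NC)ncnc21` keeps the chain of compound 2 and carries methylamino in place of methoxy on an aromatic carbon. The same methylamino group is present in compound 1, which sits at the limit > 50000 nM. That compound also has a different chain, so it is only weak guidance for the direction of this change.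

In this assay, a modest weakening is therefore expected, possibly not much beyond the scatter, with an estimated step of a 2.0-fold higher number from compound 2 to compound 3 (0.30 log units; within the scatter). Compound 3 is estimated at 6500 nM, with an expected range of 2000 nM to 25000 nM.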

Compound 3, half-maximal inhibitory concentration: 4450 nM
Compound 3: the middle estimate sits 1.5-fold (0.16 log units) above what was measured; measured number inside the range.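

In this assay, the exchange of methoxy for methylamino on this aromatic carbon comes to a 1.4-fold higher number from compound 2 to compound 3 (0.14 log units; within the scatter), so with the longer chain in place the two groups cannot be told apart here, even though methylamino brings a hydrogen-bond donor that methoxy lacks. For the compounds shown here, with methylamino held constant, the chain change now stands alone for the first time, and butyl in place of hydrogen on the saturated chain carbon, six bonds along the chain from an aromatic nitrogen, gives an at least 11-fold lower number from compound 1 to compound 3 (1.05 log units; beyond the scatter), which places the large difference seen in this short series on the chain rather than on the aromatic substituent. That step is a bound and not a size, because one end of it is a limit: the limit of > 50000 nM in this assay, at which 1 of the 3 values shown sits.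

The compounds shown leave open how the response runs between these two chains and beyond them, for example with a longer chain or with a chain carrying a carboxylic acid in place of the terminal hydroxyl. They also leave open how far the tolerance on the aromatic carbon extends, for example to a free amine or to dimethylamino.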